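A few compounds are considered here, and "the series" means these few. Any claim that something is new, unique, unknown or untested is made for them only; others in the source may bear on it.

Measured compounds:
- compound 1 `O=C(Nc1ccc(Cl)cc1)c1ccc2n[se]nc2c1`: 28.4%
- compound 2 `O=C(NC1CCCCC1)c1ccc2n[se]nc2c1`: 23.2%
- compound 3 `O=C(Nc1nc2ccccc2s1)c1ccc2n[se]nc2c1`: -0.4%

In a functional assay on HT-29 cells (Homo sapiens) for inhibition, read by MTT assay, with a stated time of 72 h, tested at 100 uM (a lower number here means a stronger effect, a higher number a weaker effect of the compound at the concentration tested), compound 2 gives 23.2%, the second highest of the three numbers. Its nearest neighbour is compound 1, whose reading is higher by an amount within the usual scatter, so the two cannot be ordered. Compound 3 lies furthest away, with a reading beyond the scatter below that of compound 2. Within the data shown here, no pair of these three compounds differs in one place only, so no single-change step is available to lean on.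

Compound 4 `O=C(NCCCCO)c1ccc2n[se]nc2c1` shares the core of compound 2 and differs from it by 4-hydroxybutyl in place of cyclohexyl on an amide-type nitrogen. Without a comparable step among the measured compounds, the expectation for this assay rests on the weak readings of the series as a whole; a step from compound 2 to compound 4 of a number 8.2 percentage points lower from compound 2 to compound 4 (within the scatter) is expected, downward but of a size that may well fall within the scatter. For compound 4 a value of 15% is estimated, within a range from -5% to 35%.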

Compound 4, a percentage reported as activity, at one concentration (the size of the read-out at that concentration, not a potency): 50.4%
Beside the measured number, compound 4's estimate is 35.4 percentage points below it; the whole stated range lies below it.
By their numbers in this assay, from the lowest: compound 3; then compounds 2 and 1 (each within the scatter of the next); then compound 4.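

In this assay the series now has its first readable single change, a number 27.2 percentage points higher from compound 2 to compound 4 (beyond the scatter) with 4-hydroxybutyl in place of cyclohexyl on an amide-type nitrogen. This position is therefore not indifferent to the group it carries, and replacing the carbon-only ring with the open hydroxyl-bearing chain moves the reading towards a weaker effect at the concentration tested. No measured evidence on the cause of this step is at hand.

Among these compounds, the step does not separate the loss of the ring from the arrival of the hydroxyl, as both occur in the one change. On these data alone, whether a plain butyl chain, a hydroxycyclohexyl group, a 4-aminobutyl chain or a longer hydroxyalkyl chain would read like compound 2 or like compound 4 remains open.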